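Sulfonyl variation on the methoxy-bearing analogue of compound 2

The source may report more compounds than this note shows. Statements on the series, on what has been measured and on what is new or still open speak of the compounds shown alone.

Compound 1 `NS(=O)(=O)c1ccc(-c2oc3ccccc3c(=O)c2-c2ccccc2)cc1` gives 61% in an assay on isolated protein for inhibition of prostaglandin G/H synthase 1 (Mus musculus), tested at 10 ug/mL; a higher number here means more inhibition at the concentration tested (going by the name of the read-out), a lower number less inhibition; compound 2 `COc1ccc(-c2c(-c3ccc(S(N)(=O)=O)cc3)oc3ccccc3c2=O)cc1` gives 84% in the same assay. For the measured compounds named here, compound 2 stands highest of the two numbers known, and the only measured step, a number 23 percentage points higher from compound 1 to compound 2 (beyond the scatter), separates it from compound 1 and lies beyond the scatter.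

Compound 3 `COc1ccc(-c2c(-c3ccc(S(C)(=O)=O)cc3)oc3ccccc3c2=O)cc1` has not been measured. It differs from compound 2 in one place: methyl in place of amino on a sulfonyl sulfur. Going by the values given here, no measured step touches the sulfonyl sulfur; the single known step concerns the methoxy group on an aromatic carbon and so gives no direct guide to this change. With nothing in the series to anchor the direction, the working expectation for compound 3 in this assay is a step of a number 9 percentage points lower from compound 2 to compound 3 (within the scatter) from compound 2, kept small and uncertain. Compound 3 is therefore estimated at 75%, with a range from 50% to 95%.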

Compound 3, a percentage reported as inhibition, at one concentration (the size of the read-out at that concentration, not a potency): < 5%
Compound 3 gave a limit, no number (the forecaster's own chance of this, stated with the estimate: 0%); at least 70 percentage points between middle value and limit.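

The sulfonyl sulfur is a position where one group decides the reading in this assay: methyl in place of amino gives a number at least 79 percentage points lower from compound 2 to compound 3 (beyond the scatter). Compound 3 stands as a limit of the assay and not as a number: the limit of < 5% in this assay, at which 1 of the 3 values shown sits. The earlier step, a number 23 percentage points higher from compound 1 to compound 2 (beyond the scatter), showed only that methoxy goes with a higher reading while amino stays on the sulfonyl sulfur; this pair shows that methoxy alone, with methyl on that sulfur, does not keep the reading in compound 3.

Still open, going by these compounds, is whether anything on the sulfonyl sulfur other than amino keeps the inhibition, for instance methylamino, dimethylamino or a longer chain such as ethyl. Also open, on these data alone, is whether the same change from sulfamoyl to methylsulfonyl costs as much on the core of compound 1, which carries no methoxy.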